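Swapping chloro for fluoro on the arylsulfonyl compound

The source may hold more compounds than are shown below. What is called first, only, known or untested is meant among the compounds shown, and "the series" means these compounds.

compound 1 `Cn1c(=O)c(S(=O)(=O)Cc2ccc(F)cc2)cc2cnc(Nc3ccc4[nH]ccc4c3)nc21` gives 30000 nM
compound 2 `Cn1c(=O)c(S(=O)(=O)c2ccc(Cl)cc2)cc2cnc(Nc3ccc4[nH]ccc4c3)nc21` gives 100 nM

In a functional assay on K562 cells (Homo sapiens) for inhibition, read by trypan blue exclusion, with a stated time of 72 h (on this read-out lower numbers stand for stronger inhibition and higher numbers for weaker inhibition), compound 2 stands at 100 nM and holds the lower of the two numbers, with compound 1 far above it. Compound 3 `Cn1c(=O)c(S(=O)(=O)c2ccc(F)cc2)cc2cnc(Nc3ccc4[nH]ccc4c3)nc21` differs from compound 2 by one exchange, fluoro in place of chloro on an aromatic carbon (fluoro in place of chloro on an aromatic carbon, para to a large group). For the measured compounds named here, the only measured step is large, a 300-fold lower number from compound 1 to compound 2 (2.48 log units; beyond the scatter) (4-chlorophenyl in place of 4-fluorobenzyl on a sulfonyl sulfur). Going by the values given here, that step replaces the whole group on the sulfonyl sulfur, and no measured pair isolates the halogen, so it gives little guide to size here. The expectation therefore stays close to compound 2 at 100 nM with no clear direction, and no step beyond the scatter is expected. The expected step is a 1.2-fold higher number from compound 2 to compound 3 (0.08 log units; within the scatter) in this assay on this reasoning. Compound 3 is estimated at 120 nM (expected range 40 nM to 400 nM) in this assay when measured.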

Compound 3, half-maximal inhibitory concentration: 200 nM
Estimate against measurement, compound 3: 1.7-fold (0.22 log units) below; low and high end bracket the measured number.
By their numbers in this assay, from the lowest: compounds 2 and 3 (each within the scatter of the next); then compound 1.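

In this assay the halogen is now isolated: fluoro in place of chloro on an aromatic carbon, para to a large group, gives a 2.0-fold higher number from compound 2 to compound 3 (0.30 log units; within the scatter) and stays within the scatter, so this position does not separate the two halogens. The pair of compound 1 and compound 3 carries fluoro on both sides, and 4-fluorophenyl in place of 4-fluorobenzyl on the sulfonyl sulfur still gives a 150-fold lower number from compound 1 to compound 3 (2.18 log units; beyond the scatter), so the large step does not depend on the change of halogen. Nothing measured here accounts for either step.

The compounds shown leave open how a methoxy group, an amine or a carboxylic acid in place of the halogen would read in this assay. They also leave open how a longer chain between the sulfonyl sulfur and the aromatic ring would read.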